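The compounds below may be only part of what the source reports. "The series", "measured", "known", "first", "only" and "open" are said of these compounds alone.

Measured compounds:
- compound 1 `CCCCC[Se]c1nc(N)c2ccccc2n1`: > 100000 nM
- compound 2 `C[Se]c1nc(N)c2ccccc2n1`: > 100000 nM
- compound 3 `C[Se]c1nc(N)c2cccnc2n1`: > 100000 nM

In a functional assay on CCRF-CEM cells (Homo sapiens) for cytotoxicity, read by MTT assay, with a stated time of 72 h (a lower number here means that less compound is tolerated, a higher number that more compound is tolerated), compound 1 gives only a limit of the assay, > 100000 nM, and not a number. Compound 2 likewise gives only a limit, > 100000 nM. Compound 3 also gives only a limit, > 100000 nM. All three values sit at the same limit, (the limit of > 100000 nM in this assay, at which 3 of the 3 values shown sit), so no step between them can be read: the step that the two limits leave unreadable from compound 1 to compound 2 is unreadable for this reason.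

Compound 4 `CCCCC[Se]c1nc(NCc2ccccc2)c2ccccc2n1` differs from compound 1 by benzyl in place of hydrogen on a nitrogen on an aromatic ring. No measured step bears on this change; the only measured step, from compound 1 to compound 2, concerns the chain on the selenium and is itself unreadable, so the size and direction of the step in this assay cannot be drawn from the shown data. The expected step is an at least 1.2-fold lower number from compound 1 to compound 4 (0.09 log units; that floor lies within the scatter), judged as small, within the scatter. Compound 4 is therefore expected to give about 80000 nM, with a range from 20000 nM to 300000 nM, and quite possibly again only a limit.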

Compound 4, concentration lethal to 50% of the cells: > 100000 nM
Compound 4 ended at the assay's limit; the forecaster's own chance of this, stated with the estimate: 55%; middle value at least 1.2-fold (0.09 log units) from the limit.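

In this assay compound 4 and compound 1 both stop at a limit and give no number, so no step between them can be read: the limit of > 100000 nM in this assay, at which 4 of the 4 values shown sit.

The compounds shown leave open whether benzyl in place of hydrogen, or any other change among them, makes any difference to cytotoxicity in this assay.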